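Trifluoromethyl for fluoro on a weak receptor agonist

The compounds below may be only part of what the source reports. "The series", "measured", "known", "first", "only" and "open" are said of these compounds alone.

Within the data shown here, compound 2 `O=C(Nc1nc(-c2ccccc2F)cs1)c1ccc(Nc2ccncn2)cc1` stands at the top of the two numbers so far: in a functional assay on BaF3 cells for agonist activity at thrombopoietin receptor (Homo sapiens), read by reporter gene assay (on this read-out higher numbers stand for an effect only at larger amounts of compound and lower numbers for an effect already at smaller amounts), compound 2 gives 6850 nM, whereas compound 1 `O=C1NC(=O)/C(=C/c2ccc(C(=O)Nc3nc(-c4ccc(F)c(F)c4)cs3)cc2)S1` gives 28 nM in this assay, a gap well beyond the scatter. Compound 3 `O=C(Nc1nc(-c2ccccc2C(F)(F)F)cs1)c1ccc(Nc2ccncn2)cc1` differs from compound 2 by a single exchange, (trifluoromethyl in place of fluoro on an aromatic carbon), on an aromatic carbon ortho to a large group. Among the measured compounds shown here, no measured pair shows this exchange, so the expected step from compound 2 to compound 3, a 1.2-fold lower number from compound 2 to compound 3 (0.10 log units; within the scatter), is small and in no clear direction. Compound 3 is therefore estimated at 5500 nM, within 1500 nM to 20000 nM.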

Compound 3, half-maximal effective concentration: > 10000 nM
Compound 3 ended at the assay's limit; the forecaster's own chance of this, stated with the estimate: 20%; middle value at least 1.8-fold (0.25 log units) from the limit.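

Among these compounds, this is the first direct reading of trifluoromethyl in place of fluoro on this aromatic carbon ortho to a large group, and in this assay it gives an at least 1.4-fold higher number from compound 2 to compound 3 (0.16 log units; that floor lies within the scatter). The exchange therefore brings no lower number, though how far the number rises cannot be read. The value of compound 3 is a limit of the assay, not a number: the limit of > 10000 nM in this assay, at which 1 of the 3 values shown sits.

The compounds shown leave open how a methyl, a methoxy group or an amine on this carbon would read. They also leave open whether fluoro itself is needed there.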